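The source may report more compounds than this note shows. Statements on the series, on what has been measured and on what is new or still open speak of the compounds shown alone.

Compound 1 `CN(C)CCCCCN(C)C1=Nc2ccccc2C(CC(=O)NCc2ccccc2)N1c1ccc(-c2ccccn2)cc1` — in a functional assay on SK-OV-3 cells (Homo sapiens) for cytotoxicity, read by MTT assay, with a stated time of 48 h (a lower number here means a stronger inhibitor, a higher number a weaker inhibitor), compound 1 gives 2410 nM
Compound 2 `CN(C)CCN1CCN(C2=Nc3ccccc3C(CC(=O)NCc3ccccc3)N2c2ccc(-c3ccccc3)cc2)CC1` — in this assay compound 2 gives 1970 nM

Both compounds were tested in the same cell-based readout, and the two numbers lie within the scatter of each other, so neither can be called the stronger inhibitor on this evidence. Compound 2 is the starting point for the step that follows.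

Compound 3 `CN(C)CCN1CCN(C2=Nc3ccccc3C(CC(=O)NCc3ccncc3)N2c2ccc(-c3ccccc3)cc2)CC1` differs from compound 2 in one place only: pyridin-4-yl in place of phenyl on a saturated chain carbon bound to an amide-type nitrogen. The rest of the molecule, including the shared core and the side chain bearing two basic nitrogens, is unchanged. Among the measured compounds shown here, no pair of measured compounds shows this exchange, so there is no measured step to lean on, and the expectation rests on the change being a single ring atom swap at the outer end of the amide substituent.

For compound 3 the expected change from compound 2 is a 1.3-fold higher number from compound 2 to compound 3 (0.10 log units; within the scatter), that is, a step not beyond the scatter in either direction. Compound 3 is therefore estimated at 2500 nM in this assay, with a range from 1000 nM to 6500 nM.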

Compound 3, half-maximal inhibitory concentration: 11700 nM
The estimate for compound 3 lay 4.7-fold (0.67 log units) below the measured number, and the stated range ends below it.
By their numbers in this assay, from the lowest: compounds 2 and 1 (each within the scatter of the next); then compound 3.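

The outer ring of the amide substituent is not a neutral spot. In this assay, exchanging phenyl for pyridin-4-yl, which replaces one ring carbon with nitrogen and adds one hydrogen-bond acceptor, gives a 5.9-fold higher number from compound 2 to compound 3 (0.77 log units; beyond the scatter), so compound 3 is the weaker inhibitor of the pair. Compounds 1 and 2 differ in more than one place and could not isolate any single group, whereas this pair shows that a change of one ring atom on a saturated chain carbon bound to an amide-type nitrogen can, with the rest of the molecule held constant, move the number beyond the scatter. Nothing available here explains why this exchange has that effect.

The compounds shown leave open whether any ring nitrogen at this place gives the same result, or whether it depends on the nitrogen's place in the ring, as pyridin-3-yl or pyridin-2-yl would test, and whether a 4-fluorophenyl or 4-methoxyphenyl ring would behave like phenyl or like pyridin-4-yl. They also leave open whether the same exchange would give a similar step on the side chain of compound 1, since it has been read only on the side chain of compound 2.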